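The compounds below may be only part of what the source reports. "The series", "measured", "known", "first", "only" and "open" are said of these compounds alone.

Measured compounds in a functional assay on RAW264.7 cells (Mus musculus) for inhibition, read by spectrophotometry and Griess assay, with a stated time of 24 h; on this read-out lower numbers stand for stronger inhibition and higher numbers for weaker inhibition:

Compound 1 `COc1cc(CCC(=O)C[C@@H](O)CCc2ccc(O)cc2)ccc1O` — 37500 nM
Compound 2 `CC(=O)O[C@H](CCc1ccc(O)cc1)C[C@H](O)CCc1ccc(O)cc1` — 32000 nM
Compound 3 `CC(=O)O[C@H](CCc1ccc(O)c(O)c1)C[C@H](O)CCc1ccc(O)cc1` — 9520 nM

Compounds 1 and 2 share neither core in a way that is broken down here; the difference between the two cores is not broken down here. Their values in this assay lie within the scatter of each other, so no order is read between compound 1 and compound 2.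

Within the series built on compound 2, one change has been measured: hydroxy in place of hydrogen on an aromatic carbon. That change gave a 3.4-fold lower number from compound 2 to compound 3 (0.53 log units; beyond the scatter), a modest step, yet beyond the scatter.

Compound 4 `COc1cc(CCC(=O)C[C@@H](O)CCc2ccc(O)c(O)c2)ccc1O` is not yet measured. It stands to compound 1 as compound 3 stands to compound 2: hydroxy in place of hydrogen on an aromatic carbon. The place lines of the two changes read the same word for word, so this is the same change made on the other core. With the change measured only once, the expectation for compound 4 rests on that single step, and the unknown is whether the core of compound 1 carries it the same way as the core of compound 2.

Compound 4 is therefore expected to show a 3.1-fold lower number from compound 1 to compound 4 (0.49 log units; beyond the scatter), taking the step seen as a 3.4-fold lower number from compound 2 to compound 3 (0.53 log units; beyond the scatter) as the guide. The estimate for compound 4 is 12000 nM, with a range from 5000 nM to 30000 nM to allow for the change behaving differently on this core.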

Compound 4, half-maximal inhibitory concentration: 9370 nM
The estimate for compound 4 lay 1.3-fold (0.11 log units) above the measured number, within the range that was stated.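

In this assay, the hydroxy group that turns 4-hydroxyphenyl into 3,4-dihydroxyphenyl gave a 4.0-fold lower number from compound 1 to compound 4 (0.60 log units; beyond the scatter), and the size of this step agrees with that of the earlier step on the other core: the same change on two cores in this assay, a 3.4-fold lower number (0.53 log units; beyond the scatter) from compound 2 to compound 3 and a 4.0-fold lower number (0.60 log units; beyond the scatter) from compound 1 to compound 4, 1.2-fold (0.08 log units) apart, within the scatter of two such steps

Across these two cores, then, the change carries over, and its size on one core served as a fair guide to its size on the other. This rests on a single pair per core in one read-out, so it does not show that the step would hold on any further core, and it gives no reason why the change acts as it does.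

Still open, on these data alone, is whether another group in the same place, such as an amine or a carboxylic acid, would give a step of similar size, or whether the effect belongs to the hydroxy group alone. Also open is whether the step would survive a longer chain in the shared core, since both pairs shown keep the chain length unchanged.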